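Formyl in place of chloro at the assay limit

A few compounds are considered here, and "the series" means these few. Any claim that something is new, unique, unknown or untested is made for them only; others in the source may bear on it.

Of the compounds shown here, three sharing one core have been tested in a functional assay on the whole organism with Mus musculus as the target; on this read-out lower numbers stand for an effect already at smaller amounts and higher numbers for an effect only at larger amounts of compound. Compound 1 `CN(c1ccncc1)n1cccc1Cl` gives > 20 mg/kg, which is a limit and not a number. Compound 2 `CCN(c1ccncc1)n1cccc1Cl` gives > 20 mg/kg, which is also a limit. Compound 3 `CCCN(c1ccncc1)n1cccc1Cl` gives > 20 mg/kg, again a limit. The whole set therefore rests at the limit of > 20 mg/kg in this assay, at which 3 of the 3 values shown sit, and compound 3 has no number of its own.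

The next compound, compound 4 `CCCN(c1ccncc1)n1cccc1C=O`, carries formyl in place of chloro on an aromatic carbon and otherwise matches compound 3: formyl in place of chloro on an aromatic carbon.

The measured steps are a step that the two limits leave unreadable from compound 1 to compound 2, a step that the two limits leave unreadable from compound 1 to compound 3 and a step that the two limits leave unreadable from compound 2 to compound 3. All three alter the saturated chain and none touches the chloro group, so they offer neither a size nor a direction for this change. Nothing shown argues for a move in either direction in this assay, and a result that stays near the limit seems the most likely outcome. The expected change is a step that the limit leaves unreadable from compound 3 to compound 4, a tentative estimate with no direction supported by the data. For compound 4 the estimated value is 25 mg/kg, with an expected range of 8 mg/kg to 60 mg/kg.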

Compound 4, dose for half-maximal effect: > 20 mg/kg
Compound 4 was reported as a limit (the forecaster's own chance of this, stated with the estimate: 65%); the middle value lies beyond the limit too.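

In this assay compound 3 gives > 20 mg/kg, which is a limit. Compound 4 gives > 20 mg/kg, also a limit, so the step between these two compounds cannot be read. The whole set now rests at one point: the limit of > 20 mg/kg in this assay, at which 4 of the 4 values shown sit.

The compounds shown leave open whether chloro and formyl differ at all on this read-out, as none of them has a measured number.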